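A few compounds are considered here, and "the series" means these few. Any claim that something is new, unique, unknown or untested is made for them only; others in the source may bear on it.

Measured in an ADME assay on S9 fraction from liver (Rattus norvegicus) for metabolic stability, read by LC-MS, using NADPH, with a stated time of 30 min; a lower number here means that less of the compound is left, a higher number that more of the compound is left:
- Compound 1 `CCCCCCCCc1ccc(OCC(=O)Cn2nnc(SC)n2)cc1`: < 5%, a limit of the assay
- Compound 2 `CCCCCCCCc1ccc(OCC(=O)Cn2nnc(-c3cccnc3)n2)cc1`: 12%
- Compound 3 `CCCCCCCCc1ccc(OCC(=O)Cn2nnc(-c3cccs3)n2)cc1`: 8%

Compound 3 stands at 8%, level with compound 2 within the scatter: a number 4 percentage points lower from compound 2 to compound 3 (within the scatter).

Next is compound 4 `CCCCCCCCc1ccc(OCC(=O)Cn2nnc(Cc3ccccc3)n2)cc1`, with benzyl in place of thiophen-2-yl on an aromatic carbon.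

Two measured steps start from a limit: a number at least 7 percentage points higher from compound 1 to compound 2 (that floor lies within the scatter), and a number at least 3 percentage points higher from compound 1 to compound 3 (that floor lies within the scatter). Going by the values given here, the closest precedent is the exchange of one ring group for another: a number 4 percentage points lower from compound 2 to compound 3 (within the scatter). Among the compounds with values here, no measured step therefore supports a change beyond the scatter in this assay, and none is expected here.

The expected step is no change at the digits printed from compound 3 to compound 4 (within the scatter).

For compound 4 the estimated value is 8%, with an expected range of 5% to 18%.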

Compound 4, percent of the compound remaining: < 5%
Compound 4 ended at the assay's limit; the forecaster's own chance of this, stated with the estimate: 30%; at least 3 percentage points between middle value and limit.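

In this assay, benzyl differs from thiophen-2-yl and pyridin-3-yl in reaching this aromatic carbon through a carbon rather than through its ring, with a number at least 3 percentage points lower from compound 3 to compound 4 (that floor lies within the scatter) and a number at least 7 percentage points lower from compound 2 to compound 4 (that floor lies within the scatter). Compound 4 gives < 5%, a limit of the assay, so an aromatic ring in the group does not by itself keep compound 4 off that limit. The step involving compound 1 cannot be read: the limit of < 5% in this assay, at which 2 of the 4 values shown sit.

Going by these compounds, whether an amine or a carboxylic acid on this aromatic carbon would leave more of the compound remaining stays open. So does the effect of any change elsewhere on the shared core.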